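From Methoxy to (Oxolan-3-yl)oxy on the Shared Core

The compounds below may be only part of what the source reports. "The series", "measured", "known", "first", "only" and "open" are said of these compounds alone.

Of the compounds shown here, three sharing one core have been tested in a functional assay on A549 cells (Homo sapiens) for antiproliferative activity, read by MTT assay, with a stated time of 72 h; on this read-out lower numbers stand for stronger inhibition and higher numbers for weaker inhibition: compound 1 (`COc1cc2ncnc(N3CCCc4ccccc43)c2cc1NC(=O)C=C(C)C`) gives 5410 nM, compound 2 (`COc1cc2ncnc(N3CCCc4ccccc43)c2cc1NC(=O)/C=C/C(C)C`) gives 3450 nM, and compound 3 (`CCC/C=C/C(=O)Nc1cc2c(N3CCCc4ccccc43)ncnc2cc1OC`) gives 1800 nM. Compound 3 has the lowest number of the three, but its lead is clear on one side only: a 3.0-fold lower number from compound 1 to compound 3 (0.48 log units; beyond the scatter). The other two steps, a 1.9-fold lower number from compound 2 to compound 3 (0.28 log units; within the scatter) and a 1.6-fold lower number from compound 1 to compound 2 (0.20 log units; within the scatter), stay within the scatter.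

Compound 4 (`CCC/C=C/C(=O)Nc1cc2c(N3CCCc4ccccc43)ncnc2cc1O[C@@H]1CCOC1`) keeps the pent-1-en-1-yl group of compound 3 and differs elsewhere: oxolan-3-yl in place of methyl on an oxygen on an aromatic ring. In words, oxolan-3-yl stands in place of methyl on an oxygen on an aromatic ring. Within the data shown here, none of the measured steps touches that oxygen, since all three alter only the group on a carbonyl carbon. They show how far this small set has moved so far, but they give no direction for the new change. The expectation therefore starts from compound 3 at 1800 nM, and no step beyond the scatter is expected, with a wide margin on either side. The estimated step is a 1.1-fold lower number from compound 3 to compound 4 (0.05 log units; within the scatter). For compound 4 the estimated value in this assay is 1600 nM, with an expected range of 550 nM to 4500 nM.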

Compound 4, half-maximal inhibitory concentration: 7320 nM
Compound 4: the middle estimate sits 4.6-fold (0.66 log units) below what was measured; the measured number lies above the stated range.
By their numbers in this assay, from the lowest: compounds 3, 2, 1 and 4 (each within the scatter of the next, the first and the last beyond it).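

In this assay the oxygen on an aromatic ring proves to be a place that responds, with a 4.1-fold higher number from compound 3 to compound 4 (0.61 log units; beyond the scatter) as the first step shown away from the group on a carbonyl carbon. With pent-1-en-1-yl held constant, methyl on that oxygen cannot be exchanged for oxolan-3-yl, with its five heavy atoms, five-membered non-aromatic ring and one hydrogen-bond acceptor, without the number rising beyond the scatter. Whether the rise goes with the size of the entering group, its ring or its oxygen cannot be told, and nothing available here accounts for it.

Going by these compounds, it remains open whether a simple ethyl or a 2-methoxyethyl group on that oxygen would give a number closer to that of compound 3 or to that of compound 4, and whether the opposite configuration at the single defined stereocentre of the oxolan-3-yl group would read the same. Also open, on these data alone, is whether the exchange would carry a similar cost with 2-methylprop-1-en-1-yl, 3-methylbut-1-en-1-yl or a dimethylamino-bearing chain on the carbonyl carbon.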